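The compounds below may be only part of what the source reports. "The series", "measured", "known", "first", "only" and "open" are said of these compounds alone.

Among the measured compounds shown here, compound 3, whose structure is `c1ccc(-c2cn[nH]c2)c(NCC2=NCCN2)c1`, stands highest of the three compounds measured so far in a functional assay with Alpha-1A adrenergic receptor (Homo sapiens) as the target, read by calcium flux (on this read-out lower numbers stand for smaller maximal responses and higher numbers for larger maximal responses), with a value of 112%. Compound 2, `Cc1n[nH]c(-c2ccccc2NCC2=NCCN2)n1`, gives 87% in this assay, and compound 1, `CCn1ccc(-c2ccccc2NCC2=NCCN2)n1`, gives 78%. The one step recorded among these, a number 25 percentage points higher from compound 2 to compound 3 (beyond the scatter), shows that the 1H-pyrazol-4-yl group carries a larger maximal response than the 3-methyl-1H-1,2,4-triazol-5-yl group. Compound 4, `Cn1ccc(-c2ccccc2NCC2=NCCN2)n1`, is not yet measured; the change from compound 3 is 1-methyl-1H-pyrazol-3-yl in place of 1H-pyrazol-4-yl on an aromatic carbon. Compound 4 differs from compound 1 only in the small alkyl group on the pyrazole nitrogen, so the value of compound 1 in this assay is the closest guide, and it lies well under that of compound 3. A downward step is therefore expected, estimated as a number 32 percentage points lower from compound 3 to compound 4 (beyond the scatter) in this assay. For compound 4 the expected value in this assay is 80%, within a range from 65% to 96%.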

Compound 4, largest response reached (reported as maximal response), in percent of the reference or control that the assay uses: 116%
For compound 4 the middle estimate is 36 percentage points below the measured one, and the stated range ends below it.
By their numbers in this assay, from the lowest: compounds 1 and 2 (each within the scatter of the next); then compounds 3 and 4 (each within the scatter of the next).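

Replacing the 1H-pyrazol-4-yl group with the 1-methyl-1H-pyrazol-3-yl group on this aromatic carbon leaves the maximal response in this assay essentially unchanged (a number 4 percentage points higher from compound 3 to compound 4 (within the scatter)), although the entering group has 0 hydrogen-bond donors and the leaving group has 1. The small alkyl group on the pyrazole nitrogen counts for much more: hydrogen in place of methyl on the saturated chain carbon bound to that nitrogen gives a large step (a number 38 percentage points higher from compound 1 to compound 4 (beyond the scatter)). The 1-methyl-1H-pyrazol-3-yl group also lies clearly above the 3-methyl-1H-1,2,4-triazol-5-yl group (a number 29 percentage points higher from compound 2 to compound 4 (beyond the scatter)).

Going by these compounds, it remains open how a longer chain such as propyl on the pyrazole nitrogen, or an amine or a carboxylic acid on the pyrazole ring, would fare in this assay. Nothing available here explains why these steps take the sizes they do.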